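The compounds below may be only part of what the source reports. "The series", "measured", "known", "first", "only" and "open" are said of these compounds alone.

Compound 1 `O=C(Nc1cc2nc(C3CCCCC3)[nH]c2cc1N1CCCC1)OCC(F)(F)F` gives, in an ADME assay on Vero cells (Chlorocebus sabaeus) for cytotoxicity, read by resazurin assay, with a stated time of 3 days (a higher number here means a weaker inhibitor, a lower number a stronger inhibitor), a limit of > 100 ug/mL.
Compound 2 `CCN(CC)c1cc2[nH]c(C3CCCCC3)nc2cc1NC(=O)OCC(F)(F)F` gives in this assay a limit of > 100 ug/mL.
Compound 3 `CN(C)c1cc2[nH]c(C3CCCCC3)nc2cc1NC(=O)c1ccc(Br)cc1` gives in this assay a limit of > 100 ug/mL.

Compound 2 therefore stands at the limit of this assay, with no number of its own; the other two values shown sit at the same limit, (the limit of > 100 ug/mL in this assay, at which 3 of the 3 values shown sit). For the measured compounds named here, the only step between measured compounds, diethylamino in place of pyrrolidin-1-yl on an aromatic carbon, is a step that the two limits leave unreadable from compound 1 to compound 2, so its size cannot be read.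

Compound 4 `CCN(CC)c1cc2[nH]c(C3CCCCC3)nc2cc1NC(=O)c1cnccn1` differs from compound 2 by pyrazin-2-yl in place of 2,2,2-trifluoroethoxy on a carbonyl carbon. Going by the values given here, no measured step touches the carbonyl carbon whose other neighbours are the amide-type nitrogen, so nothing among the measured steps bears directly on this change. Because every value shown sits at the limit of > 100 ug/mL in this assay, at which 3 of the 3 values shown sit, the account expects no step beyond the scatter and a further limit rather than a number. The step from compound 2 to compound 4 is estimated as a step that the limit leaves unreadable from compound 2 to compound 4. For compound 4 the estimate is 150 ug/mL, within 60 ug/mL to 400 ug/mL.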

Compound 4, half-maximal inhibitory concentration: > 100 ug/mL
Compound 4: a limit, no number (the forecaster's own chance of this, stated with the estimate: 80%); the middle value lies beyond the limit too.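

In this assay compound 4 gives > 100 ug/mL, which is a limit and not a number. The step from compound 2 to compound 4 therefore cannot be read, and no new step follows: the limit of > 100 ug/mL in this assay, at which 4 of the 4 values shown sit.

The compounds shown leave open whether any one of them differs from another in this assay.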